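The source may hold more compounds than are shown below. What is called first, only, known or untested is meant among the compounds shown, and "the series" means these compounds.

Working notes on the series, read in an ADME assay on HEK293 cells (Homo sapiens) for cytotoxicity, read by MTT assay, with a stated time of 72 h; a higher number here means a weaker inhibitor, a lower number a stronger inhibitor. Compound 1 `O=C(CN1CCN(C(=O)c2ccc(Br)cc2)CC1)N1CCN(CCCc2c[nH]c3ccc(F)cc23)CC1` gives 60500 nM, and compound 2 `O=C(CN1CCN(C(=O)c2ccc(F)cc2)CC1)N1CCN(CCCc2c[nH]c3ccc(F)cc23)CC1` gives 102000 nM. Only these two numbers exist so far, and they lie within the scatter of each other, so compound 2 cannot be separated from compound 1.

Compound 3 `O=C(CN1CCN(C(=O)c2cccc(F)c2)CC1)N1CCN(CCCc2c[nH]c3ccc(F)cc23)CC1` shares its core with compound 2 and differs in one place: 3-fluorophenyl in place of 4-fluorophenyl on a carbonyl carbon, (3-fluorophenyl in place of 4-fluorophenyl on a carbonyl carbon). The two have the same atoms, joined differently.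

Going by the values given here, one measured step bears on this change: a 1.7-fold higher number from compound 1 to compound 2 (0.23 log units; within the scatter). It exchanges bromo for fluoro on the same aromatic ring and stays within the scatter. Among the compounds with values here, it does not move a group around that ring, so it is only indirect evidence, and no measured step tests the fluoro shift itself. On that limited basis, no change beyond the scatter is expected in this assay.

The expected step is a 1.1-fold lower number from compound 2 to compound 3 (0.05 log units; within the scatter). Compound 3 is estimated at 90000 nM, with an expected range of 45000 nM to 170000 nM.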

Compound 3, half-maximal inhibitory concentration: 83000 nM
Beside the measured number, compound 3's estimate is 1.1-fold (0.04 log units) above it; measured number inside the range.
By their numbers in this assay, from the lowest: compounds 1, 3 and 2 (each within the scatter of the next).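

In this assay, the shift from 4-fluorophenyl to 3-fluorophenyl on the carbonyl carbon now has a direct reading: a 1.2-fold lower number from compound 2 to compound 3 (0.09 log units; within the scatter). This means that the two arrangements of the same atoms cannot be separated at this position, whereas the earlier step tested only an exchange of bromo for fluoro. The exchange of 4-bromophenyl for 3-fluorophenyl at the same carbon, a 1.4-fold higher number from compound 1 to compound 3 (0.14 log units; within the scatter), also stays within the scatter, and no supporting measurement bears on why these numbers lie so close together.

The compounds shown carry only fluoro or bromo on this phenyl ring, so it remains open whether an amine, a carboxylic acid or a methoxy group there would give a step beyond the scatter in this assay. Also open, from the compounds shown here alone, are the reading of a 3-bromophenyl group on the same carbonyl carbon and the effect of a longer chain on the shared core.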